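The compounds below may be only part of what the source reports. "The series", "measured", "known", "first", "only" and "open" are said of these compounds alone.

Measured so far:
- compound 1 `NCCCCNCCCN(Cc1cccc(-c2ccccc2)c1)Cc1cccc(-c2ccccc2)c1`: 30300 nM
- compound 2 `NCCCCN(CCCN(Cc1ccc(F)cc1)Cc1ccc(F)cc1)CCCN(Cc1ccc(F)cc1)Cc1ccc(F)cc1`: 1500 nM

In an ADME assay on RAW264.7 cells (Mus musculus) for cytotoxicity, read by resazurin assay, with a stated time of 48 h (on this read-out lower numbers stand for higher toxicity in this test and higher numbers for lower toxicity in this test), compound 2 gives 1500 nM, the lower of the two numbers; compound 1 gives 30300 nM, a gap beyond the scatter. Compound 3 `NC1CCC(N(CCCN(Cc2ccc(F)cc2)Cc2ccc(F)cc2)CCCN(Cc2ccc(F)cc2)Cc2ccc(F)cc2)CC1` is not yet measured. It differs from compound 2 by 4-aminocyclohexyl in place of 4-aminobutyl on an amine nitrogen. Among the compounds with values here, no pair of measured compounds shows what this kind of change does, so the expected step from compound 2 to compound 3 in this assay is no change at the digits printed from compound 2 to compound 3 (within the scatter), not beyond the scatter in either direction. Compound 3 is therefore estimated at 1500 nM, with a range from 600 nM to 4000 nM.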

Compound 3, half-maximal cytotoxic concentration: 4500 nM
Beside the measured number, compound 3's estimate is 3.0-fold (0.48 log units) below it, and the stated range ends below it.
By their numbers in this assay, from the lowest: compound 2; then compound 3; then compound 1.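

In this assay, 4-aminocyclohexyl in place of 4-aminobutyl on an amine nitrogen gives a 3.0-fold higher number from compound 2 to compound 3 (0.48 log units; beyond the scatter), so this position is not silent to a change of this group. This single step is the only one in the series that varies one place, and it moves toward lower toxicity in this test. Nothing at hand accounts for the step.

Still open, from the compounds shown here alone, is whether a longer chain such as 6-aminohexyl, or a 4-aminophenyl group, would move the number at this position. Going by these compounds, whether the same change acts alike on the core of compound 1 also remains open.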